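Working notes: second 2-fluorophenyl replacement in the series

The source may report more compounds than this note shows. Statements on the series, on what has been measured and on what is new or still open speak of the compounds shown alone.

Measured in a functional assay on SMMC-7721 cells (Homo sapiens) for cytotoxicity, read by MTT assay, with a stated time of 24 h; on this read-out lower numbers stand for stronger inhibition and higher numbers for weaker inhibition:
- compound 1 `CC(=O)Nc1ccc(S(=O)(=O)N2C/C(=C\c3ccccc3F)C(=O)/C(=C/c3ccccc3F)C2)cc1`: 7490 nM
- compound 2 `COc1cc(/C=C2\CN(S(=O)(=O)c3ccc(NC(C)=O)cc3)C/C(=C\c3ccccc3F)C2=O)cc(OC)c1OC`: 3920 nM

Among the measured compounds shown here, compound 2 stands level with compound 1, the only other measured compound. For the measured compounds named here, the single measured step between them is a 1.9-fold lower number from compound 1 to compound 2 (0.28 log units; within the scatter).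

Compound 3 `COc1cc(/C=C2\CN(S(=O)(=O)c3ccc(NC(C)=O)cc3)C/C(=C\c3cc(OC)c(OC)c(OC)c3)C2=O)cc(OC)c1` differs from compound 2 in one place, on a double-bonded chain carbon bound to a double-bonded ring carbon: 3,5-dimethoxyphenyl in place of 2-fluorophenyl on a double-bonded chain carbon bound to a double-bonded ring carbon.

The measured step bears directly on this change, since there too 2-fluorophenyl left in favour of a methoxy-bearing phenyl at this kind of place. Going by the values given here, it is the only such evidence, and it did not exceed the scatter. No shift beyond the scatter is therefore expected in this assay, and direction cannot be called. The expected size is a 1.1-fold lower number from compound 2 to compound 3 (0.05 log units; within the scatter). For compound 3 the estimate is 3500 nM, with an expected range of 1300 nM to 9500 nM.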

Compound 3, half-maximal inhibitory concentration: 4200 nM
Compound 3: middle estimate off by 1.2-fold (0.08 log units), on the low side; low and high end bracket the measured number.
By their numbers in this assay, from the lowest: compounds 2, 3 and 1 (each within the scatter of the next).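

In this assay, the change reads as a 1.1-fold higher number from compound 2 to compound 3 (0.03 log units; within the scatter): on a double-bonded chain carbon bound to a double-bonded ring carbon, 3,5-dimethoxyphenyl, with 10 heavy atoms and 2 hydrogen-bond acceptors, stands in place of 2-fluorophenyl, with 7 heavy atoms and none, without a shift beyond the scatter. Compound 3 carries no fluorine, so this read-out does not depend on a 2-fluorophenyl group being kept at this kind of place in these compounds. No supporting data bear on why the number holds across this change.

On these data alone, whether any group at this place can move the number beyond the scatter remains open. A phenyl bearing a dimethylamino group or a carboxylic acid, or an unsubstituted phenyl, would test this.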